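Chain extension on the shared core: propyl to butyl

This account rests on a few compounds, and the source may have more. Where it says the series, first, only, none or still open, it means among the compounds named here.

Compound 2 `CCCc1cc2ccccc2nc1-c1cc(-c2ccccc2)no1` gives 52500 nM in a functional assay on A549 cells (Homo sapiens) for inhibition, read by MTT assay, with a stated time of 24 h (on this read-out higher numbers stand for weaker inhibition and lower numbers for stronger inhibition), the only number shown so far in the series. In this assay compound 1 `CCc1cc2ccccc2nc1-c1cc(-c2ccccc2)no1` reaches only a limit, > 100000 nM. One of the two values shown is thus (the limit of > 100000 nM in this assay, at which 1 of the 2 values shown sits). Compound 3 `CCCCc1cc2ccccc2nc1-c1cc(-c2ccccc2)no1` differs from compound 2 by methyl in place of hydrogen on a saturated chain carbon, three bonds along the chain from an aromatic carbon, that is, propyl to butyl. For the measured compounds named here, the single measured step that bears on it is an at least 1.9-fold lower number from compound 1 to compound 2 (0.27 log units; that floor lies within the scatter), whose floor lies within the scatter. A further step of this kind is expected to give at most a modest lowering, a 1.8-fold lower number from compound 2 to compound 3 (0.24 log units; within the scatter). Compound 3 is therefore estimated at 30000 nM, with a range from 10000 nM to 100000 nM.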

Compound 3, half-maximal inhibitory concentration: > 100000 nM
Compound 3: only a limit was reported; the forecaster's own chance of this, stated with the estimate: 20%; at least 3.3-fold (0.52 log units) between middle value and limit.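

Going from propyl to butyl gives an at least 1.9-fold higher number from compound 2 to compound 3 (0.27 log units; that floor lies within the scatter) in this assay, so the earlier chain extension towards a lower number is not followed by a second one, although the floor of this step lies within the scatter. Compound 3 thus goes against any steady trend with chain length, and the step from compound 1 to compound 3 cannot be read. Most of the series now rests on a limit rather than a number: the limit of > 100000 nM in this assay, at which 2 of the 3 values shown sit.

Open, from the compounds shown here alone, is how a longer chain, or an amine at the end of the chain, would read in this assay. Going by these compounds, with a number for compound 2 alone, the size of any chain-length optimum also stays open.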